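Sec-Butyl for Dimethoxypropyl on the Core of Compound 1

A few compounds are considered here, and "the series" means these few. Any claim that something is new, unique, unknown or untested is made for them only; others in the source may bear on it.

Three measured compounds share a core that carries an aminophenyl benzamide arm. Compound 1 `COC(CCn1cnc2c(NCc3ccc(C(=O)Nc4ccccc4N)cc3)nc(Cl)nc21)OC` was tested in a functional assay on HepG2 cells (Homo sapiens) for antiproliferative activity, read by CCK-8 assay, with a stated time of 72 h, tested at 2 uM (on this read-out higher numbers stand for a stronger effect at the one concentration tested and lower numbers for a weaker effect), and compound 1 gives 8.52%. Compound 2 `CC(C)n1cnc2c(Nc3ccccc3)nc(NCOCc3ccc(C(=O)Nc4ccccc4N)cc3)nc21` gives 6.58% in this assay, and compound 3 `CCCCn1cnc2c(Nc3cccc(Cl)c3)nc(NCOCc3ccc(/C=C/C(=O)Nc4ccccc4N)cc3)nc21` gives 20.5%. Among these three numbers compound 1 stands second highest: its value and that of compound 2 lie within the scatter of each other, so no order between them can be read, while compound 3 lies beyond the scatter above compound 1.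

Compound 4 `CCC(C)n1cnc2c(NCc3ccc(C(=O)Nc4ccccc4N)cc3)nc(Cl)nc21` has not yet been measured. It differs from compound 1 in one place (sec-butyl in place of 3,3-dimethoxypropyl on an aromatic nitrogen). Among the compounds with values here, no measured pair in this set shows what such a change does, so any expectation rests on the low readings of compounds 1 and 2 alone. The step from compound 1 to compound 4 is expected to be small, a number 1.5 percentage points higher from compound 1 to compound 4 (within the scatter), in no clear direction beyond the scatter. Compound 4 is therefore estimated at 10% in this assay, within a range from 2% to 22%.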

Compound 4, a percentage reported as inhibition, at one concentration (the size of the read-out at that concentration, not a potency): 45%
Compound 4: middle estimate off by 35 percentage points, on the low side, outside the stated range (above it).
By their numbers in this assay, from the lowest: compounds 2 and 1 (each within the scatter of the next); then compound 3; then compound 4.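

In this assay, the group on the aromatic nitrogen of the five-membered ring proves able to move the reading by a wide margin: sec-butyl in place of 3,3-dimethoxypropyl gives a number 36.5 percentage points higher from compound 1 to compound 4 (beyond the scatter) and lifts the core of compound 1 clear of the scatter. The earlier compounds shown here could not show this, since none of them formed a pair differing in this one place. The change replaces a chain of 7 heavy atoms and 2 hydrogen-bond acceptors with a group of 4 carbon atoms and no acceptors, but nothing measured here bears on why the reading rises.

From the compounds shown here alone, whether the rise belongs to sec-butyl itself or would also come with a plain propyl chain, a 3-methoxypropyl chain or a cyclopentyl ring remains open. Also open, going by these compounds, is whether the same change would carry over to the differently substituted cores of compound 2 and compound 3.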